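Fluoro for chloro on the fused ring: compound 3

The source may hold more compounds than are shown below. What is called first, only, known or untested is meant among the compounds shown, and "the series" means these compounds.

Two compounds are in hand: compound 1 `Cc1ccc2occ(C3N=C(c4ccccc4)SS3)c(=O)c2c1` and compound 2 `O=c1c(C2N=C(c3ccccc3)SS2)coc2ccc(Cl)cc12`. In a functional assay on OVCAR-3 cells (Homo sapiens) for inhibition, read by sulforhodamine B assay, with a stated time of 48 h (a higher number here means a weaker inhibitor, a lower number a stronger inhibitor), compound 1 gives 93700 nM and compound 2 gives 66500 nM. Compound 2 is the only other measured point, and the step of a 1.4-fold lower number from compound 1 to compound 2 (0.15 log units; within the scatter) lies within the scatter, so the two cannot be ranked. Compound 3 `O=c1c(C2N=C(c3ccccc3)SS2)coc2ccc(F)cc12` differs from compound 2 by fluoro in place of chloro on an aromatic carbon. Among the compounds with values here, only that single substituent exchange at the same place bears on this change, and it was small, so no shift beyond the scatter in this assay is expected for compound 3. The expected value for compound 3 is 80000 nM, range 35000 nM to 180000 nM, which means an expected step of a 1.2-fold higher number from compound 2 to compound 3 (0.08 log units; within the scatter).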

Compound 3, half-maximal inhibitory concentration: > 100000 nM
Compound 3 was reported as a limit; the forecaster's own chance of this, stated with the estimate: 15%; middle value at least 1.2-fold (0.09 log units) from the limit.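

In this assay compound 3 gives > 100000 nM, which is a limit of the assay and not a number. Fluoro for chloro gives an at least 1.5-fold higher number from compound 2 to compound 3 (0.17 log units; that floor lies within the scatter), and fluoro for methyl gives an at least 1.0-fold higher number from compound 1 to compound 3 (0.02 log units; that floor lies within the scatter); both are floors within the scatter, so the true size of either step stays unknown and the three substituents at this place cannot be ranked. The reading for fluoro is bounded only from one side: the limit of > 100000 nM in this assay, at which 1 of the 3 values shown sits.

On these data alone, whether an amine or a carboxylic acid on this aromatic carbon would shift the number beyond the scatter stays open. So does the actual value of compound 3.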